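Inverting Two Ring Stereocentres in a Lysophospholipid-Type Agonist

A few compounds are considered here, and "the series" means these few. Any claim that something is new, unique, unknown or untested is made for them only; others in the source may bear on it.

Of the compounds shown here, three have been measured in an assay on HEK293 cells for agonist activity at putative P2Y purinoceptor 10 (Mus musculus), with a stated time of 1 h; on this read-out lower numbers stand for smaller maximal responses and higher numbers for larger maximal responses. Compound 1 `CCCCCCCC/C=C\CCCCCCCC(=O)OC[C@H](C)OP(=O)(O)OC[C@H](N)C(=O)O` gives 11.3%, and compound 2 `CCCCCCCC/C=C\CCCCCCCC(=O)O[C@@H](C)COP(=O)(O)OC[C@H](N)C(=O)O` gives 11.6% in this assay. Compound 3 `CCCCCCCCCCCOc1ccccc1CCC(=O)O[C@H]1CCOC[C@H]1OP(=O)(O)OC[C@H](N)C(=O)O` gives 3.2% in this assay, which puts it at the low end of the three numbers, although its gap to compound 1 and its gap to compound 2 both lie within the scatter of repeated measurements, so no order among the three can be claimed.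

Compound 4 `CCCCCCCCCCCOc1ccccc1CCC(=O)O[C@@H]1CCOC[C@@H]1OP(=O)(O)OC[C@H](N)C(=O)O` has not yet been measured in this assay. It differs from compound 3 in the following way: the two compounds have the same atoms and bonds; at least one stereo element is drawn with a configuration in one of them and without one in the other: 2 of 4 stereo elements differ; a stereocentre at a saturated ring carbon is drawn S in compound 3 and R in compound 4; a stereocentre at a saturated ring carbon is drawn R in compound 3 and S in compound 4. Among the measured compounds shown here, no step between two measured compounds is available for this kind of change, so the expectation rests on compound 3 alone. With the same atoms and bonds and only the two ring stereocentres reversed, the writer expects no step beyond the scatter, in either direction, and places compound 4 at 5%, with a range from 0% to 16%. This estimate implies an expected step of a number 1.8 percentage points higher from compound 3 to compound 4 (within the scatter).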

Compound 4, largest response reached (Emax), in percent of the reference or control that the assay uses: 19.3%
Compound 4: the middle estimate sits 14.3 percentage points below what was measured; the measured number lies above the stated range.
By their numbers in this assay, from the lowest: compounds 3, 1, 2 and 4 (each within the scatter of the next, the first and the last beyond it).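

In this assay, reversing the two stereocentres at saturated ring carbons, with atoms and bonds unchanged, gives a number 16.1 percentage points higher from compound 3 to compound 4 (beyond the scatter). Configuration at these two ring carbons alone can therefore shift the maximal response by more than the scatter, which compounds 1, 2 and 3, all within the scatter of one another, could not show. One point limits how far the step can be read as a clean comparison of two configurations: the fact that one of compounds 3 and 4 is drawn with a defined configuration and the other without, at the place where they differ.

From the compounds shown here alone, it remains open which of the two ring stereocentres carries the step, and whether a compound with only one of them reversed would sit with compound 3 or with compound 4. Going by these compounds, it is also open whether the same reversal would give a similar step with a phosphonate in place of the phosphate.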